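Swapping a Phenyl for Bromophenoxy on a Mannosidase Inhibitor

The source may hold more compounds than are shown below. What is called first, only, known or untested is meant among the compounds shown, and "the series" means these compounds.

Compound 1 `OC[C@H](NC[C@H]1N[C@H](CO)[C@H](O)[C@@H]1O)c1ccccc1` and compound 2 `O[C@H]1[C@@H](O)CN[C@@H]1CN[C@@H](COCc1ccccc1)c1ccccc1` share the same core and differ in the side chain. In an assay on isolated protein for inhibition of alpha-mannosidase 2 (Homo sapiens) (on this read-out lower numbers stand for stronger inhibition and higher numbers for weaker inhibition), compound 1 gives 11800 nM, while compound 2 gives 68300 nM, the higher of the two numbers and a gap beyond the scatter. Compound 3 `O[C@H]1[C@@H](O)CN[C@@H]1CN[C@@H](COCOc1cccc(Br)c1)c1ccccc1` differs from compound 2 by one change: 3-bromophenoxy in place of phenyl on a saturated chain carbon bound to an oxygen on a saturated carbon. For the measured compounds named here, no measured pair shows a change of this kind, so the step of a 1.2-fold lower number from compound 2 to compound 3 (0.09 log units; within the scatter) is expected to be small, within the scatter. Compound 3 is therefore expected to give about 55000 nM in this assay, with a range from 15000 nM to 200000 nM.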

Compound 3, inhibition constant: 12800 nM
For compound 3 the middle estimate is 4.3-fold (0.63 log units) above the measured one, and the stated range ends above it.
By their numbers in this assay, from the lowest: compounds 1 and 3 (each within the scatter of the next); then compound 2.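

In this assay, for the compounds shown here, 3-bromophenoxy in place of phenyl on a saturated chain carbon bound to an oxygen on a saturated carbon gives a 5.3-fold lower number from compound 2 to compound 3 (0.73 log units; beyond the scatter) and is the only measured change of this kind. The result shows that a change at this position can move the read-out beyond the scatter, and that a larger group here can go with a lower number. Nothing at hand accounts for this step.

The compounds shown do not separate the part played by the bromine from that of the added oxygen. A plain phenoxy group in the same place would tell these apart.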